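This account rests on a few compounds, and the source may have more. Where it says the series, first, only, none or still open, it means among the compounds named here.

Compound 1, `C=CC(=O)Nc1cccc(Nc2nc(N/N=C(\C)c3ccc(F)cc3)ncc2Cl)c1`, in an ADME assay on HT-29 cells (Homo sapiens) for inhibition, read by MTT assay, with a stated time of 72 h (a lower number here means a stronger inhibitor, a higher number a weaker inhibitor), gives 5050 nM.
Compound 2, `COc1ccc(/C=N/Nc2ncc(Cl)c(Nc3cccc(NC(=O)/C=C/CN(C)C)c3)n2)cc1`, in this assay gives 4820 nM.

Compound 2 holds the lower of the two numbers, yet the number of compound 1 lies so close that the two fall within the usual scatter and cannot be told apart. Compound 3, `C/C(=N\Nc1ncc(Cl)c(Nc2cccc(NC(=O)/C=C/CN(C)C)c2)n1)c1ccc(F)cc1`, has not yet been measured in this assay. It differs from compound 2 in a group of 10 heavy atoms (8 carbon, 1 nitrogen, 1 fluorine; one six-membered aromatic ring of carbon only) in place of a group of 10 heavy atoms (8 carbon, 1 nitrogen, 1 oxygen; one six-membered aromatic ring of carbon only), on a nitrogen on an aromatic ring. Among the compounds with values here, the entering group, with its fluorine, is the one already present in compound 1, which otherwise carries a different amide side chain than compound 2. Within the data shown here, no pair of measured compounds differing in only one place is available, so the effect of this exchange on its own has not been isolated. Since compound 1 and compound 2 sit within the scatter of each other, a step from compound 2 to compound 3 of a 1.0-fold higher number from compound 2 to compound 3 (0.01 log units; within the scatter) is expected, that is, nothing beyond the scatter in either direction. Compound 3 is therefore estimated at 4900 nM, with a range from 2000 nM to 12000 nM.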

Compound 3, half-maximal inhibitory concentration: 10200 nM
Estimate against measurement, compound 3: 2.1-fold (0.32 log units) below; measured number inside the range.
By their numbers in this assay, from the lowest: compounds 2 and 1 (each within the scatter of the next); then compound 3.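

Compound 3 differs from each earlier compound in one place only, so two changes can now be read separately in this assay, which the close values of compound 1 and compound 2, differing in two places, could not offer. On a nitrogen on an aromatic ring, the group with fluorine in place of the group with oxygen gives a 2.1-fold higher number from compound 2 to compound 3 (0.33 log units; beyond the scatter), and on a carbonyl carbon, 3-(dimethylamino)prop-1-en-1-yl in place of vinyl gives a 2.0-fold higher number from compound 1 to compound 3 (0.31 log units; beyond the scatter), so each change, though modest, goes beyond the scatter towards a weaker inhibitor. No measurement at hand offers a reason for either step.

The compounds shown leave open whether the group with oxygen would behave the same way alongside the vinyl side chain, since that pairing is absent here and each step is seen in one setting only. They also leave open how a chlorine in place of the fluorine, or a piperidine in place of the dimethylamino group, would shift the number.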